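Removing the Aminoalkyl Ether Side Chain from Compound 3

The source may report more compounds than this note shows. Statements on the series, on what has been measured and on what is new or still open speak of the compounds shown alone.

Three compounds sharing one core were tested in a functional assay on MDA-MB-231 cells (Homo sapiens) for inhibition, read by sulforhodamine B assay, with a stated time of 48 h; a lower number here means a stronger inhibitor, a higher number a weaker inhibitor. Compound 1 `COc1ccc(C(O)(Cc2ccc(F)cc2)c2cccc3ccccc23)c(OC)c1OC` gives 5440 nM, compound 2 `COc1ccc(C(O)(C/C=C\c2ccccc2)c2cccc3ccccc23)c(OC)c1OC` gives 12800 nM, and compound 3 `COc1ccc(C(c2ccc(OC(C)CN(C)C)cc2)c2cccc3ccccc23)c(OC)c1OC` gives 4340 nM, the lowest of the three numbers; its gap to compound 1 is within the scatter, while its gap to compound 2 lies beyond it. Within the data shown here, the only step between measured compounds, a 2.4-fold higher number from compound 1 to compound 2 (0.37 log units; beyond the scatter), concerns a different part of the molecule. Compound 4 `COc1ccc(C(c2ccc(O)cc2)c2cccc3ccccc23)c(OC)c1OC` differs from compound 3 by hydrogen in place of 1-((dimethylamino)methyl)ethyl on an oxygen on an aromatic ring. Among the measured compounds shown here, no measured step bears on this change, so the expectation rests only on the spread of the numbers seen. A modest rise is expected, a 2.1-fold higher number from compound 3 to compound 4 (0.32 log units; beyond the scatter). Compound 4 is therefore estimated at 9000 nM, within 3000 nM to 30000 nM.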

Compound 4, half-maximal inhibitory concentration: 17400 nM
The estimate for compound 4 lay 1.9-fold (0.29 log units) below the measured number; measured number inside the range.
By their numbers in this assay, from the lowest: compounds 3 and 1 (each within the scatter of the next); then compounds 2 and 4 (each within the scatter of the next).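

In this assay, replacing 1-((dimethylamino)methyl)ethoxy with hydroxy gives a 4.0-fold higher number from compound 3 to compound 4 (0.60 log units; beyond the scatter) on the shared core. Among these compounds, this is the first sign that the group on this oxygen matters: the step lies beyond the scatter, though it remains modest, and the side chain's removal raises the number. Nothing available explains this rise.

On these data alone, it remains open whether the dimethylamino group or the chain as a whole accounts for the difference. A simple ethyl ether or a carboxylic acid chain on this oxygen could help separate the two.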